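A Second Methoxy Pattern on the Carbonyl-Bound Ring

This account rests on a few compounds, and the source may have more. Where it says the series, first, only, none or still open, it means among the compounds named here.

Compound 1 `COc1ccc(-c2cc3ccccc3nc2C=O)cc1`: > 10000 nM
Compound 2 `COc1ccc(-c2cc3ccccc3nc2/C=C/C(=O)c2ccc(F)cc2)cc1`: 8320 nM
Compound 3 `COc1ccc(C(=O)/C=C/c2nc3ccccc3cc2-c2ccc(OC)cc2)cc1`: 8500 nM

In a functional assay on A549 cells (Homo sapiens) for antiproliferative activity, read by XTT assay, with a stated time of 72 h (a lower number here means a stronger inhibitor, a higher number a weaker inhibitor), compound 1 reaches only a limit of the assay, > 10000 nM. Compound 2 gives 8320 nM. Compound 3 gives 8500 nM, and the step shows a 1.0-fold higher number from compound 2 to compound 3 (0.01 log units; within the scatter). Compound 2 therefore stands beside compound 3 within the scatter, while the remaining value for compound 1 is a limit and not a number.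

Compound 4 `COc1ccc(-c2cc3ccccc3nc2/C=C/C(=O)c2c(OC)cccc2OC)cc1` differs from compound 2 by 2,6-dimethoxyphenyl in place of 4-fluorophenyl on a carbonyl carbon. Among the compounds with values here, the only measured step, a 1.0-fold higher number from compound 2 to compound 3 (0.01 log units; within the scatter), also put methoxy in place of fluoro on an aromatic carbon and left the number essentially unchanged. Within the data shown here, the change to compound 4 again brings methoxy groups onto the ring bound to the carbonyl carbon, but in a pattern that no measured step covers. On this evidence the expected step is none beyond the scatter, a 1.1-fold higher number from compound 2 to compound 4 (0.03 log units; within the scatter). Compound 4 is estimated at 9000 nM, with a range from 3000 nM to 30000 nM.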

Compound 4, half-maximal inhibitory concentration: 7410 nM
Compound 4: middle estimate off by 1.2-fold (0.08 log units), on the high side; the measured number falls inside the stated range.
By their numbers in this assay, from the lowest: compounds 4, 2 and 3 (each within the scatter of the next). At a limit, above all of these: compound 1.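

On the carbonyl carbon, 2,6-dimethoxyphenyl now stands alongside 4-fluorophenyl and 4-methoxyphenyl, and in this assay the change gives a 1.1-fold lower number from compound 2 to compound 4 (0.05 log units; within the scatter) and a 1.1-fold lower number from compound 3 to compound 4 (0.06 log units; within the scatter). Within the data shown here, the single earlier step covered only one methoxy in place of fluoro; this result shows that a ring with two methoxy groups, and more heavy atoms and hydrogen-bond acceptors than 4-fluorophenyl, also leaves the number within the scatter. Across these three rings, the position shows no measurable preference in this assay.

On these data alone, whether an amine or a carboxylic acid on this ring would move the number beyond the scatter remains open. Compound 1 remains a limit and not a number: the limit of > 10000 nM in this assay, at which 1 of the 4 values shown sits.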